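The source may report more compounds than this note shows. Statements on the series, on what has been measured and on what is new or still open speak of the compounds shown alone.

Compound 2 `CCCC#Cc1cc(C)oc(=O)c1` carries a shorter chain on the triple bond than compound 1 `CCCCCCC#Cc1cc(C)oc(=O)c1`, the two differing only in that a hydrogen replaces the propyl group on a saturated chain carbon, three bonds along the chain from a triple-bonded carbon. In a functional assay on A2780 cells (Homo sapiens) for inhibition (on this read-out higher numbers stand for weaker inhibition and lower numbers for stronger inhibition), compound 1 gives 3400 nM, and compound 2 gives 4800 nM. The step of a 1.4-fold higher number from compound 1 to compound 2 (0.15 log units; within the scatter) is small. Of the two numbers available in this assay, compound 2 holds the higher one, with compound 1 nearest to it. Compound 3 `CCCCCC#Cc1cc(C)oc(=O)c1` sits between these two chain lengths, differing from compound 2 by ethyl in place of hydrogen on a saturated chain carbon, three bonds along the chain from a triple-bonded carbon. Within the data shown here, the only step that bears on this change is a 1.4-fold higher number from compound 1 to compound 2 (0.15 log units; within the scatter), which stayed within the scatter, so no shift beyond the scatter is expected. For compound 3 the expected step is a 1.2-fold lower number from compound 2 to compound 3 (0.08 log units; within the scatter), and the estimated value in this assay is 4000 nM, with a range from 2000 nM to 8000 nM.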

Compound 3, half-maximal inhibitory concentration: 2900 nM
For compound 3 the middle estimate is 1.4-fold (0.14 log units) above the measured one, and the stated range covers the measured number.
By their numbers in this assay, from the lowest: compounds 3, 1 and 2 (each within the scatter of the next).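

In this assay, ethyl in place of hydrogen on a saturated chain carbon, three bonds along the chain from a triple-bonded carbon, comes with a 1.7-fold lower number from compound 2 to compound 3 (0.22 log units; within the scatter), and hydrogen in place of methyl, five bonds along the chain from a triple-bonded carbon, comes with a 1.2-fold lower number from compound 1 to compound 3 (0.07 log units; within the scatter). With a third chain length added, every step among these compounds stays within the scatter, so no chain length stands apart and no trend with chain length can be read. Nothing on hand beyond these numbers bears on the result.

As far as these compounds go, whether this flat reading would hold for a much longer chain remains open. So does the outcome for a chain ending in an amine or a carboxylic acid, or for a phenyl ring on the triple bond.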